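Swapping one five-membered ring for another on a shared core

This account rests on a few compounds, and the source may have more. Where it says the series, first, only, none or still open, it means among the compounds named here.

Three compounds share a common core carrying an ethylcarbamoyl group and a resorcinol-like aryl group, and differ only in the ring attached to a further aromatic carbon. Compound 1 `CCNC(=O)c1noc(-c2cc(C(C)C)c(O)cc2O)c1-c1cc(CN)no1` carries a 3-(aminomethyl)-1,2-oxazol-5-yl group; in a functional assay on A2780 cells (Homo sapiens) for inhibition (a higher number here means a weaker inhibitor, a lower number a stronger inhibitor), compound 1 has "not determined" (no result reported), and the acetylated compound 2 `CCNC(=O)c1noc(-c2cc(C(C)C)c(O)cc2O)c1-c1cc(CNC(C)=O)no1` likewise has "not determined" (no result reported) there. Among the compounds with values here, the only measured member is compound 3 `CCNC(=O)c1noc(-c2cc(C(C)C)c(O)cc2O)c1-c1cc(CN(C)C)no1`, which in this assay gives 31 nM. Compound 1 therefore stands nowhere on the numbers: it is an anchor by structure only.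

Compound 4 `CCNC(=O)c1noc(-c2cc(C(C)C)c(O)cc2O)c1-c1cnn(C(C)C)c1` arises from compound 1 by one change: 1-isopropyl-1H-pyrazol-4-yl in place of 3-(aminomethyl)-1,2-oxazol-5-yl on an aromatic carbon. Within the data shown here, with no measured step between compound 1 and any neighbour, the size of this step in this assay cannot be read from the data; the only guide is compound 3, and the expectation is a value in the same region, perhaps modestly weaker. Compound 4 is estimated at 60 nM, expected to fall between 15 nM and 300 nM.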

Compound 4, half-maximal inhibitory concentration: 21 nM
For compound 4 the middle estimate is 2.9-fold (0.46 log units) above the measured one, within the range that was stated.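

In this assay the exchange of 3-((dimethylamino)methyl)-1,2-oxazol-5-yl for 1-isopropyl-1H-pyrazol-4-yl gives a 1.5-fold lower number from compound 3 to compound 4 (0.17 log units; within the scatter) and thus no change that can be told from scatter. At this position, then, the dimethylaminomethyl group and the oxazole ring that carries it can both be replaced at once, and the number stays in the same range with a ring that has no amine on it. The step from compound 1 to compound 4 cannot be read, and no measurement shown here explains the result.

On these data alone, what a cyclopropyl group or a longer chain would do in place of the isopropyl remains open. So does the effect of a carboxylic acid or a morpholine on the pyrazole at this position.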